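Aryl phosphate exchange on the azido nucleoside scaffold

The source may report more compounds than this note shows. Statements on the series, on what has been measured and on what is new or still open speak of the compounds shown alone.

Three compounds have been examined in a physicochemical assay for metabolic stability, read by HPLC; a higher number here means that the compound lasts longer, a lower number that the compound disappears faster. Compound 1 `O=c1ccn([C@H]2CC[C@@H](COP(=O)(O)Oc3cccnc3)O2)c(=O)[nH]1` gives 50.2 h, and compound 3 `Nc1ncnc2c1ncn2[C@H]1CC[C@@H](COP(=O)(O)Oc2ccccc2)O1` gives 36.1 h. Compound 2 `Cc1ncccc1OP(=O)(O)OC[C@H]1O[C@@H](n2cc(C)c(=O)[nH]c2=O)C[C@@H]1N=[N+]=[N-]` gives 15.8 h, the lowest of the three numbers, standing beyond the scatter below both compound 3 and compound 1. The unmeasured compound 4 `Cc1cn([C@H]2C[C@H](N=[N+]=[N-])[C@@H](COP(=O)(O)Oc3ccc(Cl)cc3)O2)c(=O)[nH]c1=O` differs from compound 2 in one place: 4-chlorophenyl in place of 2-methylpyridin-3-yl on an oxygen. For the measured compounds named here, no pair of measured compounds differs in only one place, so no measured step guides this change directly. The account expects, for the step from compound 2 to compound 4, an estimated change of a 1.3-fold higher number from compound 2 to compound 4 (0.10 log units; within the scatter), small enough that it may stay within the scatter. Compound 4 is therefore estimated at 20 h, with an expected range from 8 h to 45 h.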

Compound 4, half-life: 5.5 h
Compound 4: the middle estimate sits 3.6-fold (0.56 log units) above what was measured; measured number below the stated range.
By their numbers in this assay, from the lowest: compound 4; then compound 2; then compounds 3 and 1 (each within the scatter of the next).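

On the oxygen whose other neighbour is phosphorus, the aryl group matters: in this assay, 4-chlorophenyl in place of 2-methylpyridin-3-yl gives a 2.9-fold lower number from compound 2 to compound 4 (0.46 log units; beyond the scatter), the first single-place step available here. This places the group exchange beyond the scatter on the azido scaffold, although it rests on one pair. Nothing measured on these compounds accounts for the step. From the compounds shown here alone, the exchange alters the ring nitrogen, the methyl and the chlorine together, so their separate contributions remain open. Going by these compounds, how a plain pyridin-3-yl or a 4-methoxyphenyl would read at this place also remains open.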